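The source may hold more compounds than are shown below. What is called first, only, known or untested is meant among the compounds shown, and "the series" means these compounds.

Of the compounds shown here, three have been measured in an assay on ileum with muscarinic acetylcholine receptor M3 (Cavia porcellus) as the target; on this read-out lower numbers stand for stronger inhibition and higher numbers for weaker inhibition. Compound 1 `c1ccc(C(CCN2CCCCC2)c2ccccc2)cc1` gives 69.6 nM. Compound 2 `CCc1nccn1CCC(C(N)=O)(c1ccccc1)c1ccccc1` gives 78.1 nM, the second highest of the three numbers; the gap to compound 1 is within the scatter, so the two cannot be ranked. Compound 3 `CCCc1nccn1CCC(C(N)=O)(c1ccccc1)c1ccccc1` gives 177 nM, and the step of a 2.3-fold higher number from compound 2 to compound 3 (0.36 log units; beyond the scatter) is a modest weakening that lies beyond the scatter.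

Compound 4 `Cc1cncn1CCC(C(N)=O)(c1ccccc1)c1ccccc1` has not yet been measured in this assay. It differs from compound 2 by 5-methyl-1H-imidazol-1-yl in place of 2-ethyl-1H-imidazol-1-yl on a saturated chain carbon, three bonds along the chain from two aromatic carbons and a carbonyl carbon. Going by the values given here, no measured pair shows exactly this change. Among the compounds with values here, the only step on the same ring, a 2.3-fold higher number from compound 2 to compound 3 (0.36 log units; beyond the scatter), concerns lengthening the chain on the ring rather than moving a shorter group to another ring position, so it bears on the question only loosely; it does show that small edits here move the number by modest amounts. A step of similar size or smaller is therefore expected, in either direction. Compound 4 is estimated at 100 nM, within 40 nM to 250 nM, which means an expected step of a 1.3-fold higher number from compound 2 to compound 4 (0.11 log units; within the scatter).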

Compound 4, antagonist equilibrium constant: 0.86 nM
Beside the measured number, compound 4's estimate is 120-fold (2.07 log units) above it; the measured number lies below the stated range.
By their numbers in this assay, from the lowest: compound 4; then compounds 1 and 2 (each within the scatter of the next); then compound 3.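

In this assay, going by these compounds alone, the imidazole group on this saturated chain carbon turns out to matter far more than the earlier compounds showed: replacing 2-ethyl-1H-imidazol-1-yl with 5-methyl-1H-imidazol-1-yl gives a 91-fold lower number from compound 2 to compound 4 (1.96 log units; beyond the scatter), and replacing the 2-propyl-1H-imidazol-1-yl group with it gives a 210-fold lower number from compound 3 to compound 4 (2.31 log units; beyond the scatter). Both steps dwarf the modest 2.3-fold higher number from compound 2 to compound 3 (0.36 log units; beyond the scatter) seen when the chain on the ring was lengthened, so the ring's substitution can shift this read-out strongly, not just slightly. No measurement shown here accounts for this large drop in the number.

The change alters the length of the ring's chain and its ring position together, so the compounds shown leave open which of the two drives the step. A 2-methyl-1H-imidazol-1-yl or a 5-ethyl-1H-imidazol-1-yl group at this place would separate them.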